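A few compounds are considered here, and "the series" means these few. Any claim that something is new, unique, unknown or untested is made for them only; others in the source may bear on it.

Measured compounds:
- compound 1 `COc1cc(OC)c(-c2coc3cc(OCc4ccccc4C)ccc3c2=O)cc1OC` — 1860 nM
- compound 2 `COc1cc(OC)c(-c2coc3cc(OCc4ccc(C(F)(F)F)cc4)ccc3c2=O)cc1OC` — 890 nM

In a functional assay on HepG2 cells (Homo sapiens) for antiproliferative activity, read by MTT assay, with a stated time of 24 h (on this read-out higher numbers stand for weaker inhibition and lower numbers for stronger inhibition), compound 1 gives 1860 nM, the highest of the two numbers. The nearest is compound 2, which in this assay gives 890 nM; the step is a 2.1-fold lower number from compound 1 to compound 2 (0.32 log units; beyond the scatter), a modest gain that lies beyond the scatter.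

Compound 3 `COc1cc(OC)c(-c2coc3cc(OCc4cccc(C(F)(F)F)c4)ccc3c2=O)cc1OC` has not yet been measured. It differs from compound 1 by 3-(trifluoromethyl)phenyl in place of 2-methylphenyl on a saturated chain carbon bound to an oxygen on an aromatic ring. For the measured compounds named here, the one measured step that bears on it is the one from compound 1 to compound 2, where the same 2-methylphenyl is replaced by 4-(trifluoromethyl)phenyl at the same place; compound 3 carries 3-(trifluoromethyl)phenyl there instead. Nothing measured separates the two trifluoromethylphenyl groups from each other, so the step from compound 1 to compound 2 is taken as the guide, with added uncertainty.

A modest step toward a lower number in this assay is therefore expected for compound 3, about a 1.9-fold lower number from compound 1 to compound 3 (0.27 log units; within the scatter). Compound 3 is estimated at 1000 nM, with a likely range from 450 nM to 2200 nM.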

Compound 3, half-maximal inhibitory concentration: 610 nM
Compound 3: middle estimate off by 1.6-fold (0.21 log units), on the high side; the range from low to high includes it.
By their numbers in this assay, from the lowest: compounds 3 and 2 (each within the scatter of the next); then compound 1.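

In this assay the 3-(trifluoromethyl)phenyl group gives a 3.0-fold lower number from compound 1 to compound 3 (0.48 log units; beyond the scatter) at the saturated chain carbon bound to an oxygen on an aromatic ring, so a second trifluoromethyl-bearing group now gives a lower number than the 2-methylphenyl group, with a step beyond the scatter. Exchanging the 4-(trifluoromethyl)phenyl group for the 3-(trifluoromethyl)phenyl group gives a 1.5-fold lower number from compound 2 to compound 3 (0.16 log units; within the scatter) and therefore does not separate the two groups on this read-out, which means that within this pair the number does not depend on where the trifluoromethyl group sits on the ring. Nothing available bears on the reason for these steps.

As far as these compounds go, both steps from compound 1 change the substituent and its ring position together, so it remains open how much of the lower number comes from adding trifluoromethyl and how much from removing the 2-methylphenyl group. The compounds shown also leave open how an unsubstituted phenyl, a ring carrying chlorine or a methoxy group, or an amine or carboxylic acid on a longer chain would behave at this position.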